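A few compounds are considered here, and "the series" means these few. Any claim that something is new, unique, unknown or untested is made for them only; others in the source may bear on it.

Of the compounds shown here, two have been measured in an assay for inhibition of acyl-CoA:cholesterol acyltransferase (Oryctolagus cuniculus), using microsomes; on this read-out higher numbers stand for weaker inhibition and lower numbers for stronger inhibition. Compound 1 `COc1nc(C)cc(SC)c1NC(=O)N(Cc1ccc(Oc2ccc(F)cc2)cc1)C1CCCCCC1` gives 29 nM in this assay. Compound 2 `CSc1cc(C)nc(C)c1NC(=O)N(Cc1ccc(Oc2ccc(F)cc2)cc1)C1CCCCCC1`, which carries a methyl in place of the methoxy on an aromatic carbon, gives 90 nM in this assay, and the step of a 3.1-fold higher number from compound 1 to compound 2 (0.49 log units; beyond the scatter) makes compound 2 the higher of the two numbers.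

Compound 3 `Cc1ccc(NC(=O)N(Cc2ccc(Oc3ccc(F)cc3)cc2)C2CCCCCC2)c(Cl)n1` differs from compound 2 in a larger way: a group of 8 heavy atoms (6 carbon, 1 nitrogen, 1 chlorine; one six-membered aromatic ring with 1 hetero atom) in place of a group of 10 heavy atoms (8 carbon, 1 nitrogen, 1 sulfur; one six-membered aromatic ring with 1 hetero atom), on an amide-type nitrogen. For the measured compounds named here, the only measured step, from compound 1 to compound 2, changed a single small group elsewhere on the same ring, so it does not directly bear on this exchange. Going by the values given here, no measured step tells how the assay responds to this change, so the expectation for compound 3 is uncertain and wide. Compound 3 is therefore expected to give a number near 120 nM in this assay, within a range from 30 nM to 500 nM. The step from compound 2 to compound 3 is expected to be a 1.3-fold higher number from compound 2 to compound 3 (0.12 log units; within the scatter).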

Compound 3, half-maximal inhibitory concentration: 19 nM
Estimate against measurement, compound 3: 6.3-fold (0.80 log units) above; measured number below the stated range.
By their numbers in this assay, from the lowest: compounds 3 and 1 (each within the scatter of the next); then compound 2.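

On the amide-type nitrogen, the group can be replaced by 2-chloro-6-methylpyridin-3-yl, and this assay responds clearly to this exchange, with a 4.7-fold lower number from compound 2 to compound 3 (0.68 log units; beyond the scatter). Against compound 1 the same group gives a 1.5-fold lower number from compound 1 to compound 3 (0.18 log units; within the scatter), so compound 3, which is the only one of the three without sulfur, shows that sulfur is not required for a number in this range. No measurement shown here explains why these groups give these numbers.

The exchange alters more than one part of the ring at once, so the separate contributions of the chlorine, the methyl and the removed groups stay unresolved. Going by these compounds, it also remains open how this assay would respond if an amine, a nitrile or a bromine took the place of the chlorine.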